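A few compounds are considered here, and "the series" means these few. Any claim that something is new, unique, unknown or untested is made for them only; others in the source may bear on it.

Measured compounds:
compound 1 `O=C(c1cc(Cl)c(Cl)[nH]1)c1c(O)cccc1O` — 4800 nM
compound 2 `O=C(c1cc(Cl)c(Cl)[nH]1)c1c(O)ccc(Cc2cc(C(c3csc(-c4ccccc4O)n3)c3ccc(O)c(C(=O)c4cc(Cl)c(Cl)[nH]4)c3O)c(O)c(C(=O)c3cc(Cl)c(Cl)[nH]3)c2O)c1O` — 28000 nM
compound 3 `O=C(c1cc(Cl)c(Cl)[nH]1)c1c(O)ccc(C(c2csc(-c3ccccc3O)n2)c2ccc(O)c(C(=O)c3cc(Cl)c(Cl)[nH]3)c2O)c1O` — 92000 nM

In an ADME assay on MDCK cells (Canis lupus familiaris) for cytotoxicity, read by MTT assay, with a stated time of 72 h (a lower number here means a stronger inhibitor, a higher number a weaker inhibitor), compound 3 gives the highest number of the three: in this assay compound 2 gives 28000 nM and compound 1 gives 4800 nM, and the gaps from compound 3 to both of them are beyond the scatter, so compound 3 is the weakest inhibitor of the measured set.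

Compound 4 `O=C(c1cc(Cl)c(Cl)[nH]1)c1c(O)ccc(Cc2ccc(O)c(C(=O)c3cc(Cl)c(Cl)[nH]3)c2O)c1O` has not yet been measured. It differs from compound 3 in one place: a hydrogen atom in place of a group of 12 heavy atoms (9 carbon, 1 nitrogen, 1 oxygen, 1 sulfur; one five-membered aromatic ring with 2 hetero atoms, one six-membered aromatic ring of carbon only), on a saturated chain carbon bound to two aromatic carbons. For the measured compounds named here, no step between two measured compounds shows exactly this change. What the measured compounds do show is that compound 1, the smallest of them, gives the lowest number, while compound 3, which carries the group that is removed here, gives the highest. On that basis the author expects the change from compound 3 to compound 4 to lower the number in this assay by a step beyond the scatter, roughly a 3.7-fold lower number from compound 3 to compound 4 (0.57 log units; beyond the scatter), landing compound 4 somewhere near compound 2. The author's estimate for compound 4 in this assay is 25000 nM, with a range from 8000 nM to 80000 nM, and a modest chance that only a limit is reported.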

Compound 4, half-maximal inhibitory concentration: 44000 nM
Beside the measured number, compound 4's estimate is 1.8-fold (0.25 log units) below it, within the range that was stated.
By their numbers in this assay, from the lowest: compound 1; then compounds 2 and 4 (each within the scatter of the next); then compound 3.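

For the compounds shown here, at this position, on a saturated chain carbon bound to two aromatic carbons, this assay gives the first direct reading of a single change: putting a hydrogen atom in place of the group of 12 heavy atoms produces a 2.1-fold lower number from compound 3 to compound 4 (0.32 log units; beyond the scatter). The step is modest and only just clears the scatter, so removing both the five-membered aromatic ring with 2 hetero atoms and the six-membered aromatic ring of carbon only, together in one change, shifts the number only slightly, and compound 4 still gives 44000 nM. Nothing measured here accounts for the size or direction of this step.

Because the whole group leaves in a single step, the compounds shown do not separate the contribution of the five-membered ring from that of the six-membered ring or its hydroxyl group. They also leave open how the number in this assay would respond if this chain carbon carried a methyl group, an amine or a carboxylic acid in place of the hydrogen atom.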